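The compounds below may be only part of what the source reports. "The series", "measured", "known", "first", "only" and "open" are said of these compounds alone.

Two measured compounds share one core. Compound 1 `Nc1scc(CN2CCN(c3cccc(Cl)c3Cl)CC2)c1C(=O)c1ccc(Cl)cc1` and compound 2 `Nc1scc(CN2CCN(c3cccc(F)c3)CC2)c1C(=O)c1ccc(Cl)cc1` differ only in the group on the amine nitrogen in the ring. In a functional assay on CHO cells with adenosine receptor A1 (Homo sapiens) as the target, read by cAMP accumulation and immunoassay, with a stated time of 6 min, tested at 1 uM (a lower number here means a stronger effect, a higher number a weaker effect of the compound at the concentration tested), compound 1 gives -57%, and compound 2 gives -86%, the lowest of the two numbers. That swap produced a number 29 percentage points lower from compound 1 to compound 2 (beyond the scatter). Compound 3 `Nc1scc(CN2CCN(c3ccc(F)c(F)c3)CC2)c1C(=O)c1ccc(Cl)cc1` carries fluoro in place of hydrogen on an aromatic carbon. Among the compounds with values here, no measured step adds a fluoro group this way, so the single known step bears only loosely on it, and a small change, near the scatter, is expected. For compound 3 the expected step is a number 6 percentage points higher from compound 2 to compound 3 (within the scatter). Compound 3 is expected to give -80% in this assay, between -100% and -55%.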

Compound 3, a percentage reported as activity, at one concentration (the size of the read-out at that concentration, not a potency): -78%
For compound 3 the middle estimate is 2 percentage points below the measured one, and the stated range covers the measured number.
By their numbers in this assay, from the lowest: compounds 2 and 3 (each within the scatter of the next); then compound 1.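

In this assay, a fluoro group placed ortho to the existing fluoro group and para to a large group gives a number 8 percentage points higher from compound 2 to compound 3 (within the scatter), so this position takes the added atom with no change that can be told from the scatter. The 3,4-difluorophenyl group also stays clear of the 2,3-dichlorophenyl group, with a number 21 percentage points lower from compound 1 to compound 3 (beyond the scatter). No measurement shown here offers an explanation for these numbers. Going by these compounds, whether a methoxy group or an amine on that same aromatic carbon would be tolerated as well remains open.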